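The source may report more compounds than this note shows. Statements on the series, on what has been measured and on what is new or still open speak of the compounds shown alone.

Measured compounds:
compound 1, `COc1cccc(CNC(=O)c2cn(C)c3cc(-c4cn[nH]c4)ccc23)c1`: < 1 nM
compound 2, `COc1cccc(CN(C)C(=O)c2c[nH]c3cc(-c4cn[nH]c4)ccc23)c1`: 19 nM
compound 3, `COc1cccc(CNC(=O)c2cc3ccc(-c4cn[nH]c4)nc3n2CC2CC2)c1`: 280 nM

All three were tested in an assay on isolated protein for inhibition of Rho-associated protein kinase 1 (Homo sapiens); on this read-out lower numbers stand for stronger inhibition and higher numbers for weaker inhibition. The value recorded for compound 1 in this assay, < 1 nM, is a limit of the assay and not a number; compound 1 sits at the limit of < 1 nM in this assay, at which 1 of the 3 values shown sits. Compound 2 gives 19 nM in this assay and compound 3 gives 280 nM; both are numbers. Where compound 1 stands relative to them cannot be read from its own value. Among the measured compounds shown here, no two of the measured compounds differ in a single place, so no measured step is available.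

Compound 4, `COc1cccc(CNC(=O)c2cn(-c3ccccc3)c3cc(-c4cn[nH]c4)ccc23)c1`, has not yet been tested in this assay. It differs from compound 1 by phenyl in place of methyl on an aromatic nitrogen. With compound 1 known only as a limit, the expected step from compound 1 to compound 4 in this assay is given as an at least 6.0-fold higher number from compound 1 to compound 4 (0.77 log units; beyond the scatter), a loss beyond the usual scatter rather than a gain, though the absolute starting point is uncertain. Compound 4 is therefore estimated at 6 nM in this assay, with a range from 1 nM to 50 nM expected to cover most repeat measurements.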

Compound 4, half-maximal inhibitory concentration: 21 nM
Compound 4: middle estimate off by 3.5-fold (0.54 log units), on the low side, and the stated range covers the measured number.
By their numbers in this assay, from the lowest: compounds 2 and 4 (each within the scatter of the next); then compound 3. At a limit, below all of these: compound 1.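

Phenyl in place of methyl on an aromatic nitrogen, read in this assay, gives an at least 21-fold higher number from compound 1 to compound 4 (1.32 log units; beyond the scatter), the first step in the series between two compounds that differ in one place. This shows that the group on this nitrogen affects the read-out well beyond the scatter, and that the change from methyl to phenyl moves it towards weaker inhibition without abolishing it, as compound 4 gives 21 nM, a number against which further changes at this position can be read. The printed step is a lower bound on the change and not its full size: the limit of < 1 nM in this assay, at which 1 of the 4 values shown sits.

As far as these compounds go, one step cannot tell whether the loss follows the count of heavy atoms or the presence of the ring itself, so the effect of an ethyl, a cyclopropyl or a benzyl group on this nitrogen remains open. Also open, from the compounds shown here alone, is whether an amine at the end of a longer chain on this nitrogen would bring the number back towards that of compound 1.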